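The source may report more compounds than this note shows. Statements on the series, on what has been measured and on what is new or still open speak of the compounds shown alone.

Compound 2 `CCNC(=O)[C@H]1O[C@@H](n2cnc3c(NNC(=O)c4cccnc4)ncnc32)[C@H](O)[C@@H]1O` carries, on the shared core, a (pyridin-3-yl)carbonyl group. In an assay on CHO cells for displacement of a labelled ligand from adenosine receptor A3 (Homo sapiens) (a higher number here means a weaker inhibitor, a lower number a stronger inhibitor), compound 2 gives > 5000 nM, which is a limit of the assay rather than a number. Compound 1 `CCNC(=O)[C@H]1O[C@@H](n2cnc3c(NNC(=O)c4ccc(Cl)cc4)ncnc32)[C@H](O)[C@@H]1O` is the 4-chlorophenyl relative. In this assay compound 1 gives > 5000 nM, also a limit. Compound 3 `CCNC(=O)[C@H]1O[C@@H](n2cnc3c(NNC(=O)c4ccc(Br)o4)ncnc32)[C@H](O)[C@@H]1O` carries a 5-bromofuran-2-yl group instead. In this assay compound 3 gives > 5000 nM, again a limit.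

Compound 4 `CCNC(=O)[C@H]1O[C@@H](n2cnc3c(NNC(=O)c4ccc(C)o4)ncnc32)[C@H](O)[C@@H]1O` differs from compound 2 by 5-methylfuran-2-yl in place of pyridin-3-yl on a carbonyl carbon. The measured steps that bear on this change are a step that the two limits leave unreadable from compound 1 to compound 2, a step that the two limits leave unreadable from compound 1 to compound 3 and a step that the two limits leave unreadable from compound 2 to compound 3; none of them can be sized, because all three values sit at the limit of > 5000 nM in this assay, at which 3 of the 3 values shown sit. The nearest structural comparison is compound 3, whose value is likewise a limit. So nothing beyond the scatter can be expected in this assay, and the expected step that the limit leaves unreadable from compound 2 to compound 4 is set accordingly. Compound 4 is therefore estimated to give 10000 nM, with a range from 3000 nM to 50000 nM, and most likely only a limit will be reported once more.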

Compound 4, inhibition constant: > 5000 nM
Compound 4: no number, only a limit; the forecaster's own chance of this, stated with the estimate: 85%; the middle value does not contradict the limit.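

Compound 4 also stops at a limit of the assay, just as compound 1, compound 2 and compound 3 do, so no step among these four compounds can be read: the limit of > 5000 nM in this assay, at which 4 of the 4 values shown sit.

The compounds shown leave open how strong an inhibitor each one actually is in this assay, and whether the group on the carbonyl carbon matters at all.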